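Series notes: phenyl versus benzyl groups at the five-membered ring

The source may hold more compounds than are shown below. What is called first, only, known or untested is meant among the compounds shown, and "the series" means these compounds.

Measured so far in an in vitro functional assay on cells for agonist activity at Bombesin receptor subtype-3 (Homo sapiens), read by luminescence and calcium flux; on this read-out higher numbers stand for an effect only at larger amounts of compound and lower numbers for an effect already at smaller amounts:
compound 1 `O=C(O)c1ccccc1-c1ccc(CCc2ncc(Cc3ccc(Cl)cc3)[nH]2)cc1` gives 2290 nM
compound 2 `CCCCc1cnc(CCc2ccc(-c3ccccc3C(=O)O)cc2)[nH]1` gives 2710 nM
compound 3 `O=C(O)c1ccccc1-c1ccc(CCc2ncc(-c3ccccc3)[nH]2)cc1` gives 4950 nM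

Compound 3 holds the highest number of the three; its gap to compound 2 lies within the scatter (a 1.8-fold higher number from compound 2 to compound 3 (0.26 log units; within the scatter)), while its gap to compound 1 lies beyond it (a 2.2-fold higher number from compound 1 to compound 3 (0.33 log units; beyond the scatter)). Compound 4 `COc1ccccc1Cc1cnc(CCc2ccc(-c3ccccc3C(=O)O)cc2)[nH]1` differs from compound 3 by 2-methoxybenzyl in place of phenyl on an aromatic carbon. The step that bears on this most directly is a 2.2-fold higher number from compound 1 to compound 3 (0.33 log units; beyond the scatter), where 4-chlorobenzyl gave way to phenyl at this place and the number rose modestly; compound 4 runs that change the other way with a different substituted benzyl group. a 1.8-fold higher number from compound 2 to compound 3 (0.26 log units; within the scatter) points in the same direction but stays within the scatter, and a 1.2-fold higher number from compound 1 to compound 2 (0.07 log units; within the scatter) shows little separation between the two non-phenyl groups. For compound 4 a modest lowering of the number is therefore expected in this assay, about a 2.0-fold lower number from compound 3 to compound 4 (0.30 log units; within the scatter). Compound 4 is estimated at 2500 nM, with a range from 1000 nM to 6000 nM.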

Compound 4, half-maximal effective concentration: 1720 nM
For compound 4 the middle estimate is 1.5-fold (0.16 log units) above the measured one; low and high end bracket the measured number.
By their numbers in this assay, from the lowest: compounds 4, 1, 2 and 3 (each within the scatter of the next, the first and the last beyond it).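

In this assay, among these compounds, the step of a 2.9-fold lower number from compound 3 to compound 4 (0.46 log units; beyond the scatter) is the largest so far and lies beyond the scatter, so 2-methoxybenzyl now joins 4-chlorobenzyl as a second benzyl group set apart from phenyl at this carbon of the five-membered ring. The other two steps do not separate compound 4 from its neighbours: a 1.3-fold lower number from compound 1 to compound 4 (0.12 log units; within the scatter) and a 1.6-fold lower number from compound 2 to compound 4 (0.20 log units; within the scatter) both stay within the scatter, so 2-methoxybenzyl cannot be told apart from 4-chlorobenzyl or butyl at this place. No measurement at hand speaks to the reason for the step from phenyl to 2-methoxybenzyl.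

The compounds shown leave open how much of that step belongs to the benzyl carbon and how much to the methoxy group, which unsubstituted benzyl would address. Also open, as far as these compounds go, is how an amine or a carboxylic acid on the benzyl ring would read at this place.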